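The source may report more compounds than this note shows. Statements on the series, on what has been measured and on what is new or still open speak of the compounds shown alone.

Measured so far in a physicochemical assay for solubility, read by spectrophotometry, measured as kinetic solubility, at pH 8, tested at 500 uM; on this read-out higher numbers stand for higher solubility and lower numbers for lower solubility:
- Compound 1 `Cn1cc(CNC(=O)c2ccncc2Nc2cc(-c3ccc4ccn(C)c4c3)c3nccnc3c2)cn1`: 127 ug/mL
- Compound 2 `Cn1ccc2ccc(-c3cc(Nc4cnccc4C(=O)NC4CCNC(=O)C4)cc4nccnc34)cc21`: 242 ug/mL

For the measured compounds named here, with only two numbers available, compound 2 stands within the usual scatter of compound 1, so the pair cannot be ranked. Going by the values given here, the single measured step is a 1.9-fold higher number from compound 1 to compound 2 (0.28 log units; within the scatter). In that step, 2-oxopiperidin-4-yl takes the place of (1-methyl-1H-pyrazol-4-yl)methyl on an amide-type nitrogen.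

Compound 3 `Cn1ccc2ccc(-c3cc(Nc4cnccc4C(=O)NCC4COCCN4)cc4nccnc34)cc21` keeps the shared core of compound 2 and differs at that same nitrogen: (morpholin-3-yl)methyl in place of 2-oxopiperidin-4-yl on an amide-type nitrogen. In words, (morpholin-3-yl)methyl replaces 2-oxopiperidin-4-yl. Among the compounds with values here, the step to compound 2 is the only guide here, as it changed the group at the same place and stayed within the scatter. Within the data shown here, it is thin evidence, since no measured compound carries the (morpholin-3-yl)methyl group.

In this assay, no change beyond the scatter is therefore expected. The expected step is a 1.2-fold lower number from compound 2 to compound 3 (0.08 log units; within the scatter). For compound 3, the estimated value is 200 ug/mL, with an expected range of 110 ug/mL to 270 ug/mL.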

Compound 3, solubility: 239 ug/mL
Beside the measured number, compound 3's estimate is 1.2-fold (0.08 log units) below it; measured number inside the range.
By their numbers in this assay, from the lowest: compounds 1, 3 and 2 (each within the scatter of the next).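

In this assay, the swap at the amide-type nitrogen keeps the count of 7 heavy atoms and one six-membered non-aromatic ring, but the ring now has 2 hetero atoms instead of 1, the double bond outside aromatic rings is gone, and there are 2 hydrogen-bond acceptors instead of 1; even so, the step is only a 1.0-fold lower number from compound 2 to compound 3 (0.01 log units; within the scatter). A second comparison at this nitrogen, with morpholin-3-yl in place of 1-methyl-1H-pyrazol-4-yl on the saturated chain carbon, gives a 1.9-fold higher number from compound 1 to compound 3 (0.27 log units; within the scatter), so all three groups now measured at this place remain within the scatter of one another and cannot be ranked. No independent measurement is available to explain this result.

Going by these compounds, it remains open whether any group on this nitrogen can produce a step beyond the scatter, for example a carboxylic acid or a longer chain ending in a dimethylamino group. These comparisons also cover only this one place, so they say nothing about changes made elsewhere on the shared core.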